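The compounds below may be only part of what the source reports. "The series", "measured", "known", "first", "only" and "open" are said of these compounds alone.

Compound 2, `CN(C)c1ccc(C2CC(c3ccc(-n4cncn4)cc3)=NN2C(=O)c2ccc(C(F)(F)F)cc2)cc1`, carries a (4-(trifluoromethyl)phenyl)carbonyl on the ring nitrogen of its five-membered core and a 4-(1H-1,2,4-triazol-1-yl)phenyl group on the carbon across that ring. In a functional assay on MDA-MB-231 cells (Homo sapiens) for inhibition, read by sulforhodamine B assay, tested at 10 uM (on this read-out higher numbers stand for more inhibition at the one concentration tested (going by the name of the read-out) and lower numbers for less inhibition), compound 2 gives 16.7%. Within the data shown here, that is the higher of the two numbers measured so far, but the nearest other compound lies within the scatter of it: compound 1, `Cc1ccc(S(=O)(=O)N2N=C(c3ccc(N4CCN(C)CC4)cc3)CC2c2ccc(N(C)C)cc2)cc1`, which pairs a (4-methylphenyl)sulfonyl on the ring nitrogen with a 4-(4-methylpiperazin-1-yl)phenyl group, and which in this assay gives 10.7%. Compounds 1 and 2 differ in two places. Their numbers show only that both sit in the same low band.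

Compound 3, `Cc1ccc(S(=O)(=O)N2N=C(c3ccc(-n4cncn4)cc3)CC2c2ccc(N(C)C)cc2)cc1`, has not been measured. It differs from compound 2 in one place: (4-methylphenyl)sulfonyl in place of (4-(trifluoromethyl)phenyl)carbonyl on an amine nitrogen in a ring. The same (4-methylphenyl)sulfonyl already stands on compound 1, where the reading is low, and the triazolylphenyl of compound 2 stays in place.

He therefore expects the step of a number 4.7 percentage points lower from compound 2 to compound 3 (within the scatter) to be small and, if anything, slightly downward, remaining within the scatter. His estimate for compound 3 in this assay is 12%, with a range from 0% to 28%.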

Compound 3, a percentage reported as inhibition, at one concentration (the size of the read-out at that concentration, not a potency): 20.7%
For compound 3 the middle estimate is 8.7 percentage points below the measured one; measured number inside the range.
By their numbers in this assay, from the lowest: compounds 1, 2 and 3 (each within the scatter of the next).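

On the amine nitrogen in a ring, with the 4-(1H-1,2,4-triazol-1-yl)phenyl group held in place, (4-methylphenyl)sulfonyl in place of (4-(trifluoromethyl)phenyl)carbonyl gives a number 4 percentage points higher from compound 2 to compound 3 (within the scatter) in this assay, so this exchange of one aryl-bearing group for the other leaves the reading indistinguishable. The change on an aromatic carbon, 1H-1,2,4-triazol-1-yl in place of 4-methylpiperazin-1-yl, can now also be read alone and gives a number 10 percentage points higher from compound 1 to compound 3 (within the scatter), so neither single change takes the reading beyond the scatter, which the earlier pair, differing in two places, could not show. No measurement is available that would explain these readings.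

The compounds shown leave open whether a group without an aromatic ring, such as an acetyl or a longer alkyl chain, would read differently on that amine nitrogen, and whether a carboxylic acid or a primary amine in place of the 1H-1,2,4-triazol-1-yl would leave this low band. They also leave open the role of the 4-(dimethylamino)phenyl group, which all three compounds share.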